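The source may report more compounds than this note shows. Statements on the series, on what has been measured and on what is new or still open speak of the compounds shown alone.

Measured so far:
compound 1, `Cc1ccc(C(=O)C2=C(O)C(=O)N(CC(C)O)C2c2ccc(C(C)C)cc2)cc1`, 14000 nM in an assay on isolated protein for inhibition of annexin A2/S100-A10 (Homo sapiens), read by FRET, with a stated time of 5 min; a lower number here means a stronger inhibitor, a higher number a weaker inhibitor
compound 2, `O=C(C1=C(O)C(=O)N(CCCn2ccnc2)C1c1ccccc1)c1ccccc1`, > 100000 nM

Of the two, only compound 1 returns a number in this assay. Compound 2 stands at the edge of what this assay can report: its result is a limit of the assay and not a number, and it sits at the limit of > 100000 nM in this assay, at which 1 of the 2 values shown sits. The two values are therefore not comparable beyond the statement that compound 1 is measurable where compound 2 is not.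

Compound 3 (`O=C(C1=C(O)C(=O)N(CCCn2ccnc2)C1c1ccccc1)c1cccs1`) differs from compound 2 in one place: thiophen-2-yl in place of phenyl on a carbonyl carbon. Among the measured compounds shown here, no step between measured compounds is available that would show what such a change does in this assay, so its size must be guessed. The counted difference is small, and with compound 2 already at a limit, the expectation is for no step beyond the usual scatter, in no particular direction.

Compound 3 is thus expected at 150000 nM in this assay, within a range from 50000 nM to 500000 nM. The expected step is a step that the limit leaves unreadable from compound 2 to compound 3, most likely again reported only as a limit.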

Compound 3, half-maximal inhibitory concentration: 100000 nM
Beside the measured number, compound 3's estimate is 1.5-fold (0.18 log units) above it, within the range that was stated.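

Compound 2 gives > 100000 nM, which is a limit of the assay and not a number. With thiophen-2-yl in place of phenyl on a carbonyl carbon, compound 3 gives 100000 nM in this assay, so this place now has a measured number, and the change reads as a number no higher from compound 2 to compound 3 (the limit leaves the size open). Whether the change does anything beyond the usual scatter cannot be said, because one end of the step is not a number: the limit of > 100000 nM in this assay, at which 1 of the 3 values shown sits.

The compounds shown leave open whether any group on this carbonyl carbon moves the value clearly, for instance furan-2-yl, or a phenyl carrying an amine or a carboxylic acid, since only phenyl and thiophen-2-yl stand there in this pair and neither is set against a second measured number. Among the compounds shown here, they also leave open how the gap between compound 3 and compound 1 arises, as these two compounds differ in more than one place, and a single change, such as a longer chain on the ring nitrogen in place of the one in compound 3, would be needed to read any part of it.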